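Hydroxyphenyl for Bromophenyl: Compound 4 Beside Limits

The source may hold more compounds than are shown below. What is called first, only, known or untested is meant among the compounds shown, and "the series" means these compounds.

Compound 2 `COc1cc(-c2nnc3n2NC(c2ccco2)C(C(=O)c2cccc(Br)c2)S3)cc(OC)c1OC` was examined in a functional assay on HepG2 cells (Homo sapiens) for cytotoxicity, read by MTT assay, with a stated time of 48 h; a lower number here means a stronger inhibitor, a higher number a weaker inhibitor. In this assay compound 2 gives > 100000 nM, which is a limit of the assay rather than a number. Its neighbours fare alike. Compound 1 `COc1ccc(C(=O)C2Sc3nnc(-c4cc(OC)c(OC)c(OC)c4)n3NC2c2ccco2)cc1` gives > 100000 nM in this assay, again a limit. Compound 3 `COc1cccc(C(=O)C2Sc3nnc(-c4cc(OC)c(OC)c(OC)c4)n3NC2c2ccco2)c1` gives > 100000 nM in this assay, also a limit. In sum, (the limit of > 100000 nM in this assay, at which 3 of the 3 values shown sit). The steps a step that the two limits leave unreadable from compound 1 to compound 2, a step that the two limits leave unreadable from compound 1 to compound 3 and a step that the two limits leave unreadable from compound 2 to compound 3 therefore have no readable size, since both ends of each lie at the limit.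

Compound 4 `COc1cc(-c2nnc3n2NC(c2ccco2)C(C(=O)c2ccc(O)cc2)S3)cc(OC)c1OC` has not been measured. It differs from compound 2 in one place: 4-hydroxyphenyl in place of 3-bromophenyl on a carbonyl carbon. Among the compounds with values here, none of the measured steps covers this particular change, and the three that alter the same aryl group on the carbonyl carbon all run from limit to limit, so they give no size to lean on. With every neighbour at the limit, compound 4 is expected to remain there. The step that the limit leaves unreadable from compound 2 to compound 4 is accordingly estimated to be none beyond the scatter. Compound 4 is expected to give 150000 nM in this assay, within an estimated range from 40000 nM to 600000 nM, and most likely to be reported only as a limit.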

Compound 4, half-maximal inhibitory concentration: > 100000 nM
Compound 4 ended at the assay's limit; the forecaster's own chance of this, stated with the estimate: 80%; the middle value lies beyond the limit too.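

Within the data shown here, no step from compound 1, compound 2 or compound 3 to compound 4 can be read, as all four compounds stand at a limit of the assay: the limit of > 100000 nM in this assay, at which 4 of the 4 values shown sit. The compounds shown leave open whether changing the aryl group on the carbonyl carbon affects the result in this assay.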